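Replacing 3,4-dichlorophenyl with 2-fluorophenyl in compound 3

The source may hold more compounds than are shown below. What is called first, only, known or untested is meant among the compounds shown, and "the series" means these compounds.

Three compounds that share one core and differ only in the group on an amine nitrogen in a ring have been tested in a functional assay on A549 cells (Homo sapiens) for antiproliferative activity, read by MTT assay, with a stated time of 72 h; on this read-out lower numbers stand for stronger inhibition and higher numbers for weaker inhibition. Compound 1 `Nc1nc(N)c2cc(CSC(=S)N3CCN(C4CCCCC4)CC3)ccc2n1`, which carries cyclohexyl, gives 4710 nM. Compound 2 `Cc1ccc(N2CCN(C(=S)SCc3ccc4nc(N)nc(N)c4c3)CC2)cc1`, which carries 4-methylphenyl, gives 2190 nM. Compound 3 `Nc1nc(N)c2cc(CSC(=S)N3CCN(c4ccc(Cl)c(Cl)c4)CC3)ccc2n1`, which carries 3,4-dichlorophenyl, gives 2940 nM. That value lies within the scatter of both others, with a 1.3-fold higher number from compound 2 to compound 3 (0.13 log units; within the scatter) and a 1.6-fold lower number from compound 1 to compound 3 (0.20 log units; within the scatter).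

Compound 4 `Nc1nc(N)c2cc(CSC(=S)N3CCN(c4ccccc4F)CC3)ccc2n1` has not yet been measured. It changes the same place on compound 3: 2-fluorophenyl in place of 3,4-dichlorophenyl on an amine nitrogen in a ring. Only the measured steps at this place bear on the change. Going by the values given here, the one step beyond the scatter, a 2.2-fold lower number from compound 1 to compound 2 (0.33 log units; beyond the scatter), is modest, and it swaps cyclohexyl for a substituted phenyl group. The closest comparison is a swap of one substituted phenyl group for another, a 1.3-fold higher number from compound 2 to compound 3 (0.13 log units; within the scatter), which stays within the scatter. Among the compounds with values here, no measured compound carries fluorine, so the data offer no direct guide to that group. A step beyond the scatter is therefore not expected in either direction, and the estimated change in this assay is a 1.1-fold lower number from compound 3 to compound 4 (0.02 log units; within the scatter). Compound 4 is expected at about 2800 nM, with an estimated range of 1400 nM to 5600 nM.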

Compound 4, half-maximal inhibitory concentration: 6460 nM
The estimate for compound 4 lay 2.3-fold (0.36 log units) below the measured number; the measured number lies above the stated range.
By their numbers in this assay, from the lowest: compounds 2, 3, 1 and 4 (each within the scatter of the next, the first and the last beyond it).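

In this assay, going by these compounds alone, this position proves more sensitive than the earlier compounds suggested: exchanging one substituted phenyl group for another had stayed within the scatter, but 2-fluorophenyl gives a 2.2-fold higher number from compound 3 to compound 4 (0.34 log units; beyond the scatter) and a 2.9-fold higher number from compound 2 to compound 4 (0.47 log units; beyond the scatter). A phenyl ring on this nitrogen therefore does not guarantee a number close to those of compound 2 and compound 3, and the exchange of cyclohexyl for 2-fluorophenyl gives a 1.4-fold higher number from compound 1 to compound 4 (0.14 log units; within the scatter), whereas the exchange of cyclohexyl for 4-methylphenyl went beyond the scatter. No measurement shown here accounts for the difference between these phenyl groups.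

The change to compound 4 removes both chlorines and adds a fluorine at once, so the compounds shown cannot separate the effect of losing chlorine from that of adding fluorine, and an unsubstituted phenyl, 2-chlorophenyl or 4-fluorophenyl group would be needed to pull these apart. As far as these compounds go, it also remains open how groups of a different kind on this nitrogen, such as a benzyl group, a pyridine ring or a short chain ending in an amine, would read out in this assay.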